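A few compounds are considered here, and "the series" means these few. Any claim that something is new, unique, unknown or untested is made for them only; others in the source may bear on it.

Measured in an assay on CHO cells for displacement of a labelled ligand from adenosine receptor A3 (Homo sapiens), tested at 1 uM; on this read-out higher numbers stand for more inhibition at the one concentration tested (going by the name of the read-out) and lower numbers for less inhibition:
- compound 1, `O=C(Nc1nn(-c2ccccc2)c(=O)c2ccccc12)c1ccc(Cl)cc1`: 17%
- compound 2, `CC(=O)N(C(C)=O)c1nn(-c2ccccc2)c(=O)c2ccccc12`: 0%
- compound 3, `O=C(Nc1nn(-c2ccccc2)c(=O)c2ccccc12)c1ccco1`: 8%

All three numbers are low and lie within the scatter of one another; compound 3 sits between the other two, with compound 2 nearest and compound 1 furthest. Compound 4, `Nc1nn(-c2ccccc2)c(=O)c2ccccc12`, is not yet measured. It differs from compound 3 by hydrogen in place of (furan-2-yl)carbonyl on a nitrogen on an aromatic ring. Both known steps touch the same nitrogen: a number 9 percentage points lower from compound 1 to compound 3 (within the scatter) and a number 8 percentage points higher from compound 2 to compound 3 (within the scatter). Among the measured compounds shown here, neither removes the acyl group altogether, so the present step has no direct precedent, but every variation at this position so far has left this assay flat. A step of no change at the digits printed from compound 3 to compound 4 (within the scatter) is therefore expected, no more than scatter. Compound 4 is estimated at 8%, between 0% and 25%.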

Compound 4, a percentage reported as inhibition, at one concentration (the size of the read-out at that concentration, not a potency): 8%
The estimate for compound 4 equals the measured number at the digits printed; the measured number falls inside the stated range.
By their numbers in this assay, from the lowest: compounds 2, 3, 4 and 1 (each within the scatter of the next, the first and the last beyond it).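

Complete loss of the acyl group on this nitrogen gives no change at the digits printed from compound 3 to compound 4 (within the scatter) and a number 9 percentage points lower from compound 1 to compound 4 (within the scatter) in this assay so neither (furan-2-yl)carbonyl nor (4-chlorophenyl)carbonyl is set apart from hydrogen here. Amino in place of diacetylamino gives a number 8 percentage points higher from compound 2 to compound 4 (within the scatter) and so the free amino compound also stays within the scatter of the diacetylated one. Nothing at hand explains this flat result.

Still open, going by these compounds, is whether an aminoalkyl chain, a carboxylic acid or a longer alkyl chain on this nitrogen would move the number beyond the scatter. Replacing the phenyl of the shared core with another group is also untested in these compounds.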